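This account rests on a few compounds, and the source may have more. Where it says the series, first, only, none or still open, it means among the compounds named here.

Measured so far in a physicochemical assay for lipophilicity, at pH 7.4; on this read-out higher numbers stand for higher lipophilicity and lower numbers for lower lipophilicity:
- compound 1 `CCCn1nc2c(=O)[nH]c(-c3cc(S(=O)(=O)N4CCN(CC)CC4)cnc3OCCOC)nc2c1CC`: 1
- compound 2 `CCc1c2nc(-c3cc(S(=O)(=O)N4CCN(CC)CC4)cnc3OCC(C)C)[nH]c(=O)c2nn1CCOC`: 2.9

Compound 2, at 2.9, is the higher of the two values, and its gap to compound 1, at 1, lies beyond the usual scatter. These two compounds differ in more than one place, so the gap cannot be assigned to any single change.

The next compound is compound 3 `CCc1c2nc(-c3cc(S(=O)(=O)N4CCN(CC)CC4)cnc3OCCOC)[nH]c(=O)c2nn1CCOC`, still unmeasured in this assay. Relative to compound 2, it carries methoxymethyl in place of isopropyl on a saturated chain carbon bound to an oxygen on an aromatic ring. Cut one bond further out, this reads isobutoxy to 2-methoxyethoxy.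

For the measured compounds named here, no measured pair isolates this change, so its size remains a judgement. A clear downward move beyond the scatter is expected. The expectation starts from compound 2 at 2.9, while compound 1 at 1 shows the lowest reading so far. The expected step is a number 1.40 log units lower from compound 2 to compound 3 (beyond the scatter). Compound 3 is estimated at 1.5, with an expected range of 0.9 to 2.2.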

Compound 3, distribution coefficient: 1.4
Estimate against measurement, compound 3: 0.10 log units above; the measured number falls inside the stated range.
By their numbers in this assay, from the lowest: compound 1; then compound 3; then compound 2.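

Compound 3 differs in one place from each earlier compound, so single changes can now be read in this assay, where the gap between the first two compounds could not be assigned. On a saturated chain carbon bound to an oxygen on an aromatic ring, methoxymethyl in place of isopropyl gives a number 1.50 log units lower from compound 2 to compound 3 (beyond the scatter), while methoxy in place of methyl on a saturated chain carbon, two bonds along the chain from an aromatic nitrogen, gives a number 0.40 log units higher from compound 1 to compound 3 (beyond the scatter). These two changes each bring oxygen into a chain, yet they move the number in opposite directions and by different amounts, so in these compounds the direction depends on the place, and no measurement at hand accounts for either step or for that difference.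

From the compounds shown here alone, each place rests on a single pair, so it remains open whether either step would keep its size and direction on a different group at the other place. Also open, going by these compounds, is how this assay would read with a longer chain such as 3-methoxypropoxy, or with an amine or a carboxylic acid at the end of the chain, at the oxygen-bound place.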